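Methylamino in place of hydroxy on compound 1

The source may hold more compounds than are shown below. What is called first, only, known or untested is meant among the compounds shown, and "the series" means these compounds.

Among the measured compounds shown here, in a functional assay on HCT-8 cells (Homo sapiens) for antiproliferative activity, read by MTT assay, with a stated time of 48 h (a lower number here means a stronger inhibitor, a higher number a weaker inhibitor), compound 1 `C=C(c1ccc(OC)cc1NC(=O)CO)c1ccc(OC)c2c1C=CC(C)(C)O2` gives 470 nM as the higher of the two numbers so far. Compound 2 `C=C(c1ccc2c(c1)C=CC(C)(C)O2)c1ccc(OC)cc1NC(=O)CN` gives 220 nM and lies lower, beyond the scatter. Compound 3 `C=C(c1ccc(OC)cc1NC(=O)CNC)c1ccc(OC)c2c1C=CC(C)(C)O2` carries methylamino in place of hydroxy on a saturated chain carbon bound to a carbonyl carbon. For the measured compounds named here, no measured step isolates this change, so the expectation leans only on compound 2 at 220 nM and stays loose. The estimated step of a 1.6-fold lower number from compound 1 to compound 3 (0.19 log units; within the scatter) is expected to be a modest fall near the scatter. Compound 3 is estimated at 300 nM with an expected range from 100 nM to 900 nM in this series.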

Compound 3, half-maximal inhibitory concentration: 980 nM
The estimate for compound 3 lay 3.3-fold (0.51 log units) below the measured number, and the stated range ends below it.
By their numbers in this assay, from the lowest: compound 2; then compound 1; then compound 3.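

In this assay, methylamino in place of hydroxy on a saturated chain carbon bound to a carbonyl carbon gives a 2.1-fold higher number from compound 1 to compound 3 (0.32 log units; beyond the scatter) and so weakens the compound modestly. Among the compounds shown here, this is the first one-place comparison, and it shows that activity responds to the group at this position, with hydroxy the better of the two groups compared. No available evidence bears on the reason for this step. Open, going by these compounds, is how methoxy, dimethylamino or a carboxylic acid at this position would compare with hydroxy.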